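Free fraction notes: from compound 1 to compound 3

The compounds below may be only part of what the source reports. "The series", "measured", "known", "first", "only" and "open" are said of these compounds alone.

Measured in an ADME assay on brain (Rattus norvegicus) for protein binding; on this read-out lower numbers stand for a smaller free fraction and higher numbers for a larger free fraction:
compound 1 `Cc1ncccc1N1C[C@]2(CC[C@@H](CNc3cnn(-c4ccccc4F)c3)CC2)OC1=O` gives "not determined" (no result reported)
compound 2 `O=C1O[C@]2(CC[C@H](CNc3ccc(-c4ncccc4F)cn3)CC2)CN1c1cccnn1` gives 0.052

Compound 1 has no single number in this assay, so it offers no starting value. Compound 3 `O=C1O[C@]2(CC[C@H](CNc3cnn(-c4ccccc4F)c3)CC2)CN1c1ccnnc1` carries pyridazin-4-yl in place of 2-methylpyridin-3-yl on an amide-type nitrogen in a ring. Among the compounds with values here, no step between measured compounds is available, so the size of this change rests on expectation alone: no shift beyond the usual scatter is expected, with a slight lean towards a larger free fraction. Within the data shown here, the only anchor is compound 2 (0.052). For compound 3 the estimate is 0.07 (expected range 0.035 to 0.14).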

Compound 3, unbound fraction: 0.044
Compound 3: middle estimate off by 1.6-fold (0.20 log units), on the high side; the range from low to high includes it.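

In this assay compound 3 gives 0.044 but no step can be read from compound 1 to compound 3, since compound 1 has no single number there. On these data alone, what replacing 2-methylpyridin-3-yl with pyridazin-4-yl does to the free fraction stays open. No evidence bears on this result.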